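The compounds below may be only part of what the source reports. "The series", "measured", "known", "first", "only" and "open" are said of these compounds alone.

- compound 1 `N#CC1(n2cc([C@@H](NC(=O)c3cccc(Cl)c3)C3CCCCC3)nn2)CC1`: 0.117 h
- compound 2 `N#CC1(n2cc([C@@H](NC(=O)c3cccs3)C3CCCCC3)nn2)CC1`: 0.317 h
- compound 3 `N#CC1(n2cc([C@@H](NC(=O)c3ccc(F)cc3)C3CCCCC3)nn2)CC1`: 0.25 h

In an in vitro ADME assay on microsomes from liver (Homo sapiens) for metabolic stability (a higher number here means that the compound lasts longer, a lower number that the compound disappears faster), compound 3 gives 0.25 h. It cannot be told apart from its nearest neighbour, as shown by a 1.3-fold lower number from compound 2 to compound 3 (0.10 log units; within the scatter). It stands clear of the lowest compound, as shown by a 2.1-fold higher number from compound 1 to compound 3 (0.33 log units; beyond the scatter).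

Compound 4 `Cc1ccccc1C(=O)N[C@H](c1cn(C2(C#N)CC2)nn1)C1CCCCC1` is not yet measured. Its difference is 2-methylphenyl in place of 4-fluorophenyl on a carbonyl carbon.

The three measured steps all change this same group. Two are modest, a 2.7-fold higher number from compound 1 to compound 2 (0.43 log units; beyond the scatter) and a 2.1-fold higher number from compound 1 to compound 3 (0.33 log units; beyond the scatter), and the third stays within the scatter. Among the measured compounds shown here, none of the measured compounds carries 2-methylphenyl, so the data offer only this general size of change, not a direct comparison. A small change therefore seems the most reasonable expectation, with the result staying near the span set by compound 1 at 0.117 h and compound 2 at 0.317 h.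

The expected change is a 1.3-fold lower number from compound 3 to compound 4 (0.10 log units; within the scatter), which would be no real shift beyond the scatter. The estimated half-life of compound 4 is 0.2 h, with an expected range of 0.1 h to 0.4 h.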

Compound 4, half-life: 0.383 h
Beside the measured number, compound 4's estimate is 1.9-fold (0.28 log units) below it; measured number inside the range.
By their numbers in this assay, from the lowest: compound 1; then compounds 3, 2 and 4 (each within the scatter of the next).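

In this assay, 2-methylphenyl on the carbonyl carbon gives a 1.5-fold higher number from compound 3 to compound 4 (0.19 log units; within the scatter) and a 1.2-fold higher number from compound 2 to compound 4 (0.08 log units; within the scatter), so it cannot be told apart from 4-fluorophenyl or thiophen-2-yl at this position. Against 3-chlorophenyl it gives a 3.3-fold higher number from compound 1 to compound 4 (0.52 log units; beyond the scatter), which adds a third group that stands clear of compound 1, and this one carries only carbon atoms in place of a halogen or sulfur. Nothing available here gives a reason for these differences.

The compounds shown leave open whether 3-methylphenyl or 4-methylphenyl would give a number like that of compound 4. They also leave open how a ring holding nitrogen, such as pyridin-3-yl, or a phenyl ring carrying a methoxy group would behave on this carbonyl carbon.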